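Dioxolane cytosine nucleosides: a fluoro step on the base

The source may hold more compounds than are shown below. What is called first, only, known or untested is meant among the compounds shown, and "the series" means these compounds.

Measured so far:
compound 1 `C[C@]1(CO)OC[C@@H](n2ccc(N)nc2=O)O1` — 30000 nM
compound 2 `CC1(CO)OCC(n2ccc(N)nc2=O)O1` — 30000 nM

In a functional assay on CCRF-CEM cells (Homo sapiens) for inhibition (a lower number here means a stronger inhibitor, a higher number a weaker inhibitor), compound 1 gives 30000 nM. In this assay compound 2 gives 30000 nM. Among the measured compounds shown here, the single measured step, no change at the digits printed from compound 1 to compound 2 (within the scatter), separates two drawings of the same atoms and bonds, the fact that one of compounds 1 and 2 is drawn with a defined configuration and the other without, at the place where they differ being the only thing that sets them apart. Compound 1 therefore stands level with compound 2 and has no other measured neighbour.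

Compound 3 `C[C@]1(CO)OC[C@@H](n2cc(F)c(N)nc2=O)O1` differs from compound 1 by fluoro in place of hydrogen on an aromatic carbon. For the measured compounds named here, no measured step touches the base; no change at the digits printed from compound 1 to compound 2 (within the scatter) concerns only the configuration of the ring carbons and says nothing about a fluoro substituent on the aromatic ring. With nothing in the measured steps to move it either way, the expected step from compound 1 to compound 3 is no change at the digits printed from compound 1 to compound 3 (within the scatter), no change beyond the scatter. Compound 3 is accordingly estimated at 30000 nM, with a range from 10000 nM to 60000 nM in this assay.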

Compound 3, half-maximal inhibitory concentration: > 100000 nM
Compound 3 ended at the assay's limit (the forecaster's own chance of this, stated with the estimate: 55%); middle value at least 3.3-fold (0.52 log units) away from the limit.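

On the aromatic carbon ortho to an amino group, fluoro in place of hydrogen gives an at least 3.3-fold higher number from compound 1 to compound 3 (0.52 log units; beyond the scatter) in this assay, the only step shown that lies beyond the scatter and the only one on the base. This position is therefore sensitive to substitution, with the change here running toward a weaker inhibitor, whereas the earlier pair separated only this: the fact that one of compounds 1 and 2 is drawn with a defined configuration and the other without, at the place where they differ. Compound 3 stands at a limit of the assay, so the full size of the step remains unfixed: the limit of > 100000 nM in this assay, at which 1 of the 3 values shown sits.

Going by these compounds, whether the loss is specific to fluoro or follows any replacement of hydrogen on this carbon remains open, and a chloro or methyl group at the same place would bear on that. Also open, on these data alone, is whether the step carries over to the drawing of compound 2, without defined configuration.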